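Methyl for acetyl on the phenoxy arm of compound 1

The compounds below may be only part of what the source reports. "The series", "measured", "known", "first", "only" and "open" are said of these compounds alone.

Compound 1 `COc1cc2c(cc1OC)CN(S(=O)(=O)c1ccc(-n3cc(COc4ccccc4C(C)=O)nn3)cc1)CC2` is the starting point. In a functional assay on MOLT-3 cells (Homo sapiens) for cytotoxicity, read by MTT assay, with a stated time of 48 h (on this read-out lower numbers stand for stronger inhibition and higher numbers for weaker inhibition), compound 1 gives only a limit of the assay, > 50 ug/mL. Compound 2 `Cc1ccc(OCc2cn(-c3ccc(S(=O)(=O)N4CCc5ccccc5C4)cc3)nn2)cc1` likewise reaches only the limit > 50 ug/mL in this assay. Compound 3 `O=Cc1ccc(OCc2cn(-c3ccc(S(=O)(=O)N4CCc5ccccc5C4)cc3)nn2)cc1` also stops at the limit > 50 ug/mL. For the measured compounds named here, the one measured step, a step that the two limits leave unreadable from compound 2 to compound 3, therefore cannot be read in size, as the limit of > 50 ug/mL in this assay, at which 3 of the 3 values shown sit, shows. Compound 4 `COc1cc2c(cc1OC)CN(S(=O)(=O)c1ccc(-n3cc(COc4ccccc4C)nn3)cc1)CC2` differs from compound 1 by methyl in place of acetyl on an aromatic carbon. Going by the values given here, no measured step bears on this change, and nothing among the three measured compounds points to a value inside the readable range of this assay. Compound 4 is therefore expected to sit at about 70 ug/mL, within 35 ug/mL to 200 ug/mL, most probably again reported as a limit. The expected step is a step that the limit leaves unreadable from compound 1 to compound 4, none beyond the scatter.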

Compound 4, half-maximal inhibitory concentration: > 50 ug/mL
Compound 4: a limit, no number (the forecaster's own chance of this, stated with the estimate: 85%); the middle value is on the limit's open side.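

In this assay, for the compounds shown here, compound 4 gives only a limit, > 50 ug/mL, so no step from compound 1 to compound 4 can be read. The compounds shown leave open what value any of them would reach inside the readable range: the limit of > 50 ug/mL in this assay, at which 4 of the 4 values shown sit.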